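Methyl for nitro on compound 1: an untested exchange

This account rests on a few compounds, and the source may have more. Where it says the series, first, only, none or still open, it means among the compounds named here.

Measured compounds in a functional assay on SH-SY5Y cells (Homo sapiens) for cytotoxicity, read by MTT assay, with stated times of 8 h, 30 min and 12 h, tested at 5 uM; a higher number here means a stronger effect of the compound at the concentration tested, a lower number a weaker effect:
Compound 1 `N=C(NCc1ccccc1)[C@@H]1CCC(=O)N1Cc1ccc([N+](=O)[O-])cc1` gives 25.6%.
Compound 2 `N=C(NCc1ccc(O)cc1)[C@@H]1CCC(=O)N1Cc1ccc([N+](=O)[O-])cc1` gives 34.5%.
Compound 3 `COc1ccc(CNC(=N)[C@@H]2CCC(=O)N2Cc2ccc([N+](=O)[O-])cc2)cc1` gives 35.2%.

Compound 1 stands lowest of the three numbers, yet its two neighbours lie within the scatter: the step of a number 8.9 percentage points higher from compound 1 to compound 2 (within the scatter) and the step of a number 9.6 percentage points higher from compound 1 to compound 3 (within the scatter) are both small, as is the step of a number 0.7 percentage points higher from compound 2 to compound 3 (within the scatter). Among the compounds with values here, nothing among the measured compounds therefore separates one from another beyond the usual spread.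

Compound 4 `Cc1ccc(CN2C(=O)CC[C@H]2C(=N)NCc2ccccc2)cc1` is the unmeasured member. It differs from compound 1 in one place: methyl in place of nitro on an aromatic carbon. Within the data shown here, the three measured steps all concern hydroxy or methoxy entering elsewhere in the molecule, and none of them touches the aromatic carbon where the nitro sits; no measured step bears on the exchange of nitro for methyl. What the measured compounds do show is that a single small change at a six-membered aromatic ring of carbon only moved this assay by no more than the scatter. On that basis compound 4 is expected to stay near compound 1, with the step of a number 0.4 percentage points higher from compound 1 to compound 4 (within the scatter) estimated as nothing beyond the scatter. The estimate for compound 4 is 26%, within 10% to 44%.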

Compound 4, a percentage reported as activity, at one concentration (the size of the read-out at that concentration, not a potency): 24.8%
Compound 4: middle estimate off by 1.2 percentage points, on the high side; the measured number falls inside the stated range.
By their numbers in this assay, from the lowest: compounds 4, 1, 2 and 3 (each within the scatter of the next, the first and the last beyond it).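

Within the data shown here, the exchange of nitro for methyl, on an aromatic carbon para to a large group, gives in this assay a number 0.8 percentage points lower from compound 1 to compound 4 (within the scatter) and is the first measured step at this position. It shows that replacing nitro, with its three heavy atoms and two hydrogen-bond acceptors, by a single carbon with no acceptors leaves the read-out within the scatter, so in this pair the nitro group is not needed for a number of this size. Nothing among the data shown accounts for this outcome.

On these data alone, whether an amine, a carboxylic acid or a longer chain such as propyl at this aromatic carbon would also stay close to compound 1 remains open. Also open, as far as these compounds go, is whether methyl in place of nitro would read the same way in compound 2 and compound 3, which carry hydroxy and methoxy elsewhere in the molecule.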